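Phenyl for benzyl on the amide nitrogen: cytotoxicity notes

This account rests on a few compounds, and the source may have more. Where it says the series, first, only, none or still open, it means among the compounds named here.

Three compounds of the series have been run in an ADME assay on HepG2 cells (Homo sapiens) for cytotoxicity, read by CellTiter-Glo and ATP content, with a stated time of 72 h; on this read-out higher numbers stand for an effect only at larger amounts of compound and lower numbers for an effect already at smaller amounts. Compound 1 `Cc1ccc(N2CCN(C(=O)C3CCN(C(=O)c4ccc(S(C)(=O)=O)c([N+](=O)[O-])c4)CC3)CC2)cc1` gives > 27000 nM, which is a limit of the assay rather than a number. Compound 2 `CS(=O)(=O)c1ccc(C(=O)N2CCC(C(=O)N(Cc3ccccc3)Cc3ccccc3)CC2)cc1[N+](=O)[O-]` in this assay gives > 27000 nM, again a limit. Compound 3 `Cc1ccc(N2CCN(C(=O)CCCNC(=O)c3ccc(S(C)(=O)=O)c([N+](=O)[O-])c3)CC2)cc1` in this assay returns > 27000 nM, also a limit. Compound 2 thus stands at the limit of > 27000 nM in this assay, at which 3 of the 3 values shown sit. No measured pair differs in a single place, so no measured step is available; the three values show only that none of these compounds produces an effect within the tested range.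

Compound 4 `CS(=O)(=O)c1ccc(C(=O)N2CCC(C(=O)N(Cc3ccccc3)c3ccccc3)CC2)cc1[N+](=O)[O-]` is the next member to go into this assay. It differs from compound 2 by phenyl in place of benzyl on an amide-type nitrogen. The amide-type nitrogen keeps its carbonyl and saturated-chain neighbours; only the group hanging from it changes. For the measured compounds named here, with no measured step to lean on, the expectation rests on the shared standing of all three compounds at the limit of > 27000 nM in this assay, at which 3 of the 3 values shown sit. Between the two, no step beyond the scatter is expected, a step that the limit leaves unreadable from compound 2 to compound 4. Compound 4 is therefore estimated at 40000 nM, with a range from 20000 nM to 100000 nM, and this assay will most probably report only a limit once more.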

Compound 4, half-maximal effective concentration: > 27000 nM
Compound 4: a limit, no number; the forecaster's own chance of this, stated with the estimate: 85%; the middle value is on the limit's open side.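

In this assay compound 4 gives > 27000 nM, a limit and not a number. Compound 2 also stands at a limit, so no step can be read from compound 2 to compound 4: the limit of > 27000 nM in this assay, at which 4 of the 4 values shown sit.

The compounds shown leave open how far phenyl in place of benzyl on the amide-type nitrogen shifts cytotoxicity, and at what concentration any effect begins.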